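One Fluorine Swap on Two Related Cores

A few compounds are considered here, and "the series" means these few. Any claim that something is new, unique, unknown or untested is made for them only; others in the source may bear on it.

Compound 1 `CC(O)(CSc1ccc(S(F)(F)(F)(F)F)cc1)C(=O)Nc1ccc(S(F)(F)(F)(F)F)cc1` and compound 2 `CC(O)(CSc1ccc(F)cc1)C(=O)Nc1ccc(S(F)(F)(F)(F)F)cc1` share a core and differ at a single point: one fluorine atom in place of a group of 6 heavy atoms (5 fluorine, 1 sulfur; no ring), on an aromatic carbon. Compound 3 `CC(O)(CSc1ccc(S(F)(F)(F)(F)F)cc1)C(=O)Nc1cccc(S(F)(F)(F)(F)F)c1` is built from the same atoms as compound 1, joined differently; the difference between the two cores is not broken down here. Compound 4 `CC(O)(CSc1ccc(F)cc1)C(=O)Nc1cccc(S(F)(F)(F)(F)F)c1` stands to compound 3 as compound 2 stands to compound 1, carrying the same change: one fluorine atom in place of a group of 6 heavy atoms (5 fluorine, 1 sulfur; no ring), on an aromatic carbon. Among the four compounds this is the only change that appears more than once.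

All measurements come from a functional assay on LNCaP cells (Homo sapiens) for antiproliferative activity, read by propidium iodide staining, with a stated time of 96 h; on this read-out higher numbers stand for weaker inhibition and lower numbers for stronger inhibition. In this assay compound 1 gives 18300 nM. In this assay compound 2 gives 12500 nM. The step of a 1.5-fold lower number from compound 1 to compound 2 (0.17 log units; within the scatter) thus lies within the usual scatter of repeated measurements. In this assay compound 3 gives 12700 nM, a number close to that of compound 2 and within the scatter of compound 1 as well.

Because the earlier step of a 1.5-fold lower number from compound 1 to compound 2 (0.17 log units; within the scatter) made little difference, the same change on the second core is expected to make a step of about a 1.3-fold lower number from compound 3 to compound 4 (0.13 log units; within the scatter). Compound 4 is therefore estimated to give 9500 nM in this assay, with a likely range from 4500 nM to 19000 nM. For the measured compounds named here, only one measured example of this change exists here, so the expectation rests on that single step and on the close agreement between compound 1 and compound 3.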

Compound 4, half-maximal inhibitory concentration: 26900 nM
Compound 4: the middle estimate sits 2.8-fold (0.45 log units) below what was measured; measured number outside the range, above it.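

On the core of compound 3, putting fluoro in place of the group of five fluorine atoms and one sulfur atom gives a 2.1-fold higher number from compound 3 to compound 4 (0.33 log units; beyond the scatter) in this assay, so this modest step does not repeat what the same change did on the core of compound 1, and the two steps differ by more than measurement noise would explain: the same change on two cores in this assay, a 1.5-fold lower number (0.17 log units; within the scatter) from compound 1 to compound 2 and a 2.1-fold higher number (0.33 log units; beyond the scatter) from compound 3 to compound 4, 3.1-fold (0.49 log units) apart, beyond the scatter of two such steps

For these four compounds, this means that the result of the swap on one core was not a reliable guide to its result on the other, even though the two cores are built from the same atoms. For the compounds shown here, it does not show why the cores part ways, and with only one step on each core it gives no general rule for how this change behaves across the series, nor any way to say which other cores would resemble compound 1 or compound 3.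

Going by these compounds, it remains open how other groups on the same aromatic carbon, such as chloro, trifluoromethyl, nitrile or an amine, would behave on each core. On these data alone, it also remains open whether those groups would show the same disagreement between the two cores or a steadier step from one core to the other.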